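This account rests on a few compounds, and the source may have more. Where it says the series, first, only, none or still open, it means among the compounds named here.

Series notes, cytotoxicity on cervical carcinoma cells.

Compound 1, `CCCCCCCCCCCCCCNC(=O)[C@@H](NC(=O)c1nccc2ccccc12)[C@@H](C)O`, carries a tetradecyl chain on the terminal amide and an isoquinolin-1-yl group on the other carbonyl. In a functional assay on SiHa cells (Homo sapiens) for cytotoxicity, read by MTT assay, with a stated time of 48 h (on this read-out higher numbers stand for weaker inhibition and lower numbers for stronger inhibition), compound 1 gives 21600 nM. Compound 2, `CCCCCCCCCCCCCCNC(=O)[C@@H](NC(=O)c1cc2ccccc2[nH]1)[C@@H](C)O`, differs from compound 1 only by 1H-indol-2-yl in place of isoquinolin-1-yl on a carbonyl carbon. In this assay compound 2 gives 14200 nM; the step is a 1.5-fold lower number from compound 1 to compound 2 (0.18 log units; within the scatter), so the two values cannot be ordered. Compound 3, `CCCCCCCCCCCCCCCCCCNC(=O)[C@@H](NC(=O)c1nccc2ccccc12)[C@@H](C)O`, differs from compound 1 by butyl in place of hydrogen on a saturated chain carbon, ten or more bonds along the chain from an amide-type nitrogen; in this assay compound 3 gives 51200 nM, and the step is a 2.4-fold higher number from compound 1 to compound 3 (0.37 log units; beyond the scatter). Compound 3 therefore shows the highest number of the three measured, both of its steps to the others lying beyond the scatter.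

Compound 4, `CCCCCCCCCCCCCCCCCCNC(=O)[C@@H](NC(=O)c1cc2ccccc2[nH]1)[C@@H](C)O`, is not yet measured in this assay. It stands to compound 3 as compound 2 stands to compound 1: the change is 1H-indol-2-yl in place of isoquinolin-1-yl on a carbonyl carbon, and the place description is the same word for word as for the pair compound 1 to compound 2, so this is the same change made on a different core. The two cores differ by butyl in place of hydrogen on a saturated chain carbon, ten or more bonds along the chain from an amide-type nitrogen.

Going by the values given here, only one example of the change is measured, and it moved the number by a 1.5-fold lower number from compound 1 to compound 2 (0.18 log units; within the scatter). With nothing to suggest the longer chain would alter this, the expected step for compound 4 is a 1.5-fold lower number from compound 3 to compound 4 (0.18 log units; within the scatter), resting on the earlier step of a 1.5-fold lower number from compound 1 to compound 2 (0.18 log units; within the scatter) and on the value of compound 3, 51200 nM. Compound 4 is thus estimated at 34000 nM in this assay, with a plausible span from 17000 nM to 70000 nM.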

Compound 4, half-maximal inhibitory concentration: 29600 nM
For compound 4 the middle estimate is 1.1-fold (0.06 log units) above the measured one, and the stated range covers the measured number.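

Carrying the exchange of isoquinolin-1-yl for 1H-indol-2-yl over to the longer-chain core gives a 1.7-fold lower number from compound 3 to compound 4 (0.24 log units; within the scatter) in this assay, and it agrees with the step on the core of compound 1: the same change on two cores in this assay, a 1.5-fold lower number (0.18 log units; within the scatter) from compound 1 to compound 2 and a 1.7-fold lower number (0.24 log units; within the scatter) from compound 3 to compound 4, 1.1-fold (0.06 log units) apart, within the scatter of two such steps. The chain lengthening also reads alike on both carbonyl groups, with a 2.1-fold higher number from compound 2 to compound 4 (0.32 log units; beyond the scatter) matching the earlier step: the same change on two cores in this assay, a 2.4-fold higher number (0.37 log units; beyond the scatter) from compound 1 to compound 3 and a 2.1-fold higher number (0.32 log units; beyond the scatter) from compound 2 to compound 4, 1.1-fold (0.06 log units) apart, within the scatter of two such steps. Within these four compounds the two changes therefore carry from one core to the other without a detectable difference, but both steps of the ring exchange lie within the scatter, so this agreement does not establish that the exchange has any effect, and two pairs on cores differing only in chain length say nothing about cores altered elsewhere.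

Open, as far as these compounds go, is whether the chain effect extends to a shorter chain such as decyl or to a longer chain, and how a chain ending in an amine or a carboxylic acid would read. Also open, from the compounds shown here alone, is how a phenyl or pyridyl group on the carbonyl would compare with the two bicyclic groups, and what replacing the hydroxyl of the shared core would do to the number.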